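From compound 3 to compound 4: an aryl swap

A few compounds are considered here, and "the series" means these few. Any claim that something is new, unique, unknown or untested is made for them only; others in the source may bear on it.

Values in a functional assay on A549 cells (Homo sapiens) for antiproliferative activity, read by MTT assay, with a stated time of 72 h; on this read-out higher numbers stand for weaker inhibition and lower numbers for stronger inhibition:
- compound 1 `Cc1ccc(N2CCN(C(=S)SCc3ccc4nc(N)nc(N)c4c3)CC2)cc1`: 2190 nM
- compound 2 `Nc1nc(N)c2cc(CSC(=S)N3CCN(c4ccc(F)cc4)CC3)ccc2n1`: 2040 nM
- compound 3 `Nc1nc(N)c2cc(CSC(=S)N3CCN(c4ccccc4F)CC3)ccc2n1`: 6460 nM

Compound 3 gives the highest number of the three in this assay, at 6460 nM. The next analogue is compound 4 `Nc1nc(N)c2cc(CSC(=S)N3CCN(c4ccc([N+](=O)[O-])cc4)CC3)ccc2n1`, and the change is 4-nitrophenyl in place of 2-fluorophenyl on an amine nitrogen in a ring.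

For the measured compounds named here, three measured steps bear on this. The step of a 3.2-fold higher number from compound 2 to compound 3 (0.50 log units; beyond the scatter) is modest and beyond the scatter, and so is the step of a 2.9-fold higher number from compound 1 to compound 3 (0.47 log units; beyond the scatter). The step of a 1.1-fold lower number from compound 1 to compound 2 (0.03 log units; within the scatter) stays within the scatter, so 4-methylphenyl and 4-fluorophenyl are not separated here. Going by the values given here, on these three compounds alone, the two groups named with a 4 sit together, and the one 2-fluorophenyl compound stands apart. Among the compounds with values here, no measured compound carries 4-nitrophenyl, so this reading is an extrapolation and the range has to stay wide. A modest move towards a lower number is expected, of about the size of those two steps. The expected step is a 2.6-fold lower number from compound 3 to compound 4 (0.41 log units; beyond the scatter). The estimated value for compound 4 is 2500 nM, with an expected range of 1000 nM to 6000 nM.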

Compound 4, half-maximal inhibitory concentration: 1910 nM
Estimate against measurement, compound 4: 1.3-fold (0.12 log units) above, and the stated range covers the measured number.
By their numbers in this assay, from the lowest: compounds 4, 2 and 1 (each within the scatter of the next); then compound 3.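

In this assay the 4-nitrophenyl group falls in with the other groups named with a 4: the swap for 2-fluorophenyl gives a 3.4-fold lower number from compound 3 to compound 4 (0.53 log units; beyond the scatter) as a modest step, while nitro in place of fluoro gives a 1.1-fold lower number from compound 2 to compound 4 (0.03 log units; within the scatter) and nitro in place of methyl gives a 1.1-fold lower number from compound 1 to compound 4 (0.06 log units; within the scatter) with neither step separating the compounds. Methyl, fluoro and nitro therefore read alike at this place on the phenyl ring, and compound 3 at 6460 nM is now the weakest of the four, its steps to all three others lying beyond the scatter and no compound going against this grouping. Nothing available explains why the 2-fluorophenyl compound stands apart.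

For the compounds shown here, compound 3 is the only compound with a group named with a 2, so it stays open whether the higher number goes with that placing in general or with 2-fluorophenyl alone. Also open, going by these compounds, is whether the flat picture among the groups named with a 4 holds for an amine or a carboxylic acid in place of the nitro, or for a phenyl ring carrying no group at all.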